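The compounds below may be only part of what the source reports. "The series", "measured", "known", "first", "only" and "open" are said of these compounds alone.

In a functional assay on HepG2 cells (Homo sapiens) for antiproliferative activity, read by CCK-8 assay, with a stated time of 72 h (a higher number here means a weaker inhibitor, a lower number a stronger inhibitor), the three measured compounds stand as follows:

Compound 1 `Nc1ccccc1NC(=O)c1ccc(COc2ccc(Br)cc2)cc1`: > 32000 nM (a limit of the assay)
Compound 2 `Nc1ccccc1NC(=O)c1ccc(COc2ccc(F)cc2)cc1`: 3840 nM
Compound 3 `CC(C)c1ccc(OCc2ccc(C(=O)Nc3ccccc3N)cc2)cc1`: > 32000 nM (a limit of the assay)

Compound 1 gives > 32000 nM, which is a limit of the assay and not a number. Compound 3 likewise gives > 32000 nM, again only a limit. Among the compounds with values here, compound 2 gives 3840 nM, the one real number of the three. Compound 3 therefore stands at the limit of > 32000 nM in this assay, at which 2 of the 3 values shown sit, with no number of its own.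

Compound 4 `Nc1ccccc1NC(=O)c1ccc(COc2ccc(Cl)cc2)cc1` differs from compound 3 in one place: chloro in place of isopropyl on an aromatic carbon. Within the data shown here, two measured steps bear on this. an at least 8.3-fold lower number from compound 1 to compound 2 (0.92 log units; beyond the scatter), and an at least 8.3-fold higher number from compound 2 to compound 3 (0.92 log units; beyond the scatter); the remaining pair shows a step that the two limits leave unreadable from compound 1 to compound 3. So the fluoro compound gives a number while the bromo and isopropyl compounds give limits. Compound 4 carries chloro where compound 1 carries bromo and compound 2 carries fluoro, and the expectation is that compound 4 falls between those two. For compound 4 the expected step is an at least 2.6-fold lower number from compound 3 to compound 4 (0.42 log units; beyond the scatter), out of the limit into measurable range but not down to the value of compound 2. Compound 4 is therefore estimated at 12000 nM, with a range from 4000 nM to 32000 nM.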

Compound 4, half-maximal inhibitory concentration: > 32000 nM
Compound 4: a limit, no number; the forecaster's own chance of this, stated with the estimate: 35%; middle value at least 2.6-fold (0.42 log units) from the limit.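

In this assay compound 4 gives > 32000 nM, which is a limit of the assay and not a number. Replacing fluoro with chloro gives an at least 8.3-fold higher number from compound 2 to compound 4 (0.92 log units; beyond the scatter), so the measurable activity of compound 2 does not carry over to the chloro compound, and the expected middle position for chloro between fluoro and bromo is not seen. The steps among compound 1, compound 3 and compound 4 cannot be read, and fluoro is now the only one of the four groups at this place that gives a number, while the other three sit together: the limit of > 32000 nM in this assay, at which 3 of the 4 values shown sit.

As far as these compounds go, how far compound 1, compound 3 and compound 4 lie beyond that limit stays unknown, so no order can be given among bromo, chloro and isopropyl. Also open, from the compounds shown here alone, is whether activity at this place is limited to fluoro or also appears with another group, such as a methyl, a methoxy or an amine, or with plain hydrogen.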